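The source may hold more compounds than are shown below. What is called first, only, known or untested is meant among the compounds shown, and "the series" means these compounds.

Compound 2, `Cc1ccc2oc(-c3ccc(NC(=O)CN4CCN(CCCN(C)C)CC4)cc3)nc2c1`, and compound 1, `CN(C)CCCN1CCN(CC(=O)Nc2ccc(-c3nc4cc(F)ccc4o3)cc2)CC1`, share one core and differ only by fluoro in place of methyl on an aromatic carbon. In a functional assay on HepG2 cells (Homo sapiens) for cytotoxicity, read by MTT assay, with a stated time of 24 h (a lower number here means a stronger inhibitor, a higher number a weaker inhibitor), compound 2 gives 3160 nM, whereas compound 1 gives 9180 nM, so this change made a 2.9-fold higher number from compound 2 to compound 1 (0.46 log units; beyond the scatter). Compound 3, `Cc1ccc2oc(-c3ccc(NC(=O)CCl)cc3)nc2c1`, is built on a different core; how the core of compound 3 differs from that of compound 2 is not broken down here. In this assay compound 3 gives 21500 nM, the highest of the three numbers. Compound 4, `O=C(CCl)Nc1ccc(-c2nc3cc(F)ccc3o2)cc1`, has not yet been measured; it differs from compound 3 by fluoro in place of methyl on an aromatic carbon, at the same place as the change from compound 2 to compound 1. For compound 4 the expected step is a 2.6-fold higher number from compound 3 to compound 4 (0.41 log units; beyond the scatter), which rests on the measured 2.9-fold higher number from compound 2 to compound 1 (0.46 log units; beyond the scatter). Compound 4 is therefore estimated at 55000 nM, expected to fall between 20000 nM and 150000 nM.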

Compound 4, half-maximal inhibitory concentration: 8120 nM
Compound 4: the middle estimate sits 6.8-fold (0.83 log units) above what was measured; measured number below the stated range.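

Measured in this assay, fluoro in place of methyl on an aromatic carbon gives a 2.6-fold lower number from compound 3 to compound 4 (0.42 log units; beyond the scatter). Set beside the earlier step, the same change does not carry over from one core to the other, as the two steps run in opposite directions: the same change on two cores in this assay, a 2.9-fold higher number (0.46 log units; beyond the scatter) from compound 2 to compound 1 and a 2.6-fold lower number (0.42 log units; beyond the scatter) from compound 3 to compound 4, 7.7-fold (0.89 log units) apart, beyond the scatter of two such steps. In this series, then, the step seen on one core did not foretell the step on the other, but two pairs do not show why the steps part or how the change would behave on any further core.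

The compounds shown leave open how a chloro or methoxy group, or plain hydrogen, at this place would read on either core. They also leave open whether a side chain ending in another amine would follow the step from compound 2 to compound 1 or the step from compound 3 to compound 4.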